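From trifluoromethyl to chloro in an antiproliferative series

The compounds below may be only part of what the source reports. "The series", "measured", "known", "first", "only" and "open" are said of these compounds alone.

Compound 1 `Nc1ccccc1NC(=O)CCCCCCc1nc(-c2ccccc2)no1`: 960 nM
Compound 2 `Cc1ccc(-c2noc(CCCCCCC(=O)Nc3ccccc3N)n2)cc1`: 410 nM
Compound 3 `Nc1ccccc1NC(=O)CCCCCCc1nc(-c2ccc(C(F)(F)F)cc2)no1`: 29800 nM

In a functional assay on NCI-H661 cells (Homo sapiens) for antiproliferative activity, read by MTT assay, with a stated time of 72 h (a higher number here means a weaker inhibitor, a lower number a stronger inhibitor), compound 3 gives 29800 nM, the highest number of the three and so the weakest inhibitor, as its steps to both others lie beyond the scatter. Compound 4 `Nc1ccccc1NC(=O)CCCCCCc1nc(-c2ccc(Cl)cc2)no1` differs from it in one place: chloro in place of trifluoromethyl on an aromatic carbon.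

For the measured compounds named here, three measured steps bear on this change. Methyl in place of hydrogen gave only a modest shift, a 2.3-fold lower number from compound 1 to compound 2 (0.37 log units; beyond the scatter). Trifluoromethyl gave large ones, a 31-fold higher number from compound 1 to compound 3 (1.49 log units; beyond the scatter) and a 73-fold higher number from compound 2 to compound 3 (1.86 log units; beyond the scatter). Among these three compounds, trifluoromethyl alone produced a large rise. Going by the values given here, no chloro compound has been measured here, so the data show its effect only indirectly. The expectation therefore leans on compound 1 at 960 nM and compound 2 at 410 nM, and it places chloro nearer these two than compound 3. The expected change is large and towards a stronger inhibitor, namely a 20-fold lower number from compound 3 to compound 4 (1.30 log units; beyond the scatter). In this assay the estimated value for compound 4 is 1500 nM, with an expected range from 350 nM to 8000 nM.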

Compound 4, half-maximal inhibitory concentration: 11200 nM
For compound 4 the middle estimate is 7.5-fold (0.87 log units) below the measured one, and the stated range ends below it.
By their numbers in this assay, from the lowest: compound 2; then compound 1; then compound 4; then compound 3.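

In this assay, the large rise at this position no longer belongs to trifluoromethyl alone, since exchanging it for chloro recovers only a small part of the lost activity, with a 2.7-fold lower number from compound 3 to compound 4 (0.42 log units; beyond the scatter) as the modest step. Chloro also stands well apart from both hydrogen and methyl, with a 12-fold higher number from compound 1 to compound 4 (1.07 log units; beyond the scatter) and a 27-fold higher number from compound 2 to compound 4 (1.44 log units; beyond the scatter) as large steps, so the four compounds fall into a low pair, compound 2 and compound 1, and a high pair, compound 4 and compound 3. Nothing in the data shown accounts for this split between the two pairs.

The compounds shown leave open which of the two pairs is the more typical for this position, and a fluoro, methoxy or amine group in the same place would help to show whether methyl and hydrogen or chloro and trifluoromethyl are the exception. Going by these compounds, it also remains open whether the same order of the four groups would hold on a shorter or longer chain, or with a second group on the same aromatic ring.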